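This account rests on a few compounds, and the source may have more. Where it says the series, first, only, none or still open, it means among the compounds named here.

Compound 1 `Cc1cc(OCC(C)C)cc(C)c1-c1cccc(COc2ccc(OCC(=O)O)c(F)c2)c1`: "not determined" (no result reported)
Compound 2 `CCOc1cc(C)c(-c2cccc(COc3ccc(OCC(=O)O)c(F)c3)c2)c(C)c1`: 3.48

In a physicochemical assay for lipophilicity, using the shake flask method, in phosphate buffer, measured as octanol-water partition, with a stated time of 24 h, at pH 7.4, tested at 100 uM (a lower number here means a more polar compound, a higher number a more lipophilic compound), compound 2 gives 3.48. Within the data shown here, this is the only number available, and compound 1 has no reported result, so compound 2 cannot yet be ranked against anything. It stands alone as the single reference point.

Compound 3 `Cc1cc(O)cc(C)c1-c1cccc(COc2ccc(OCC(=O)O)c(F)c2)c1` keeps the shared core and differs from compound 2 in one place: hydrogen in place of ethyl on an oxygen on an aromatic ring. Hydrogen takes the place of ethyl on an oxygen on an aromatic ring, which turns ethoxy into hydroxy. Among the measured compounds shown here, no measured pair here shows this kind of change. The expectation rests on the structural change alone. A clear downward step in this assay is expected, larger than the usual scatter, and its estimated size is a number 0.98 log units lower from compound 2 to compound 3 (beyond the scatter). Compound 3 is expected at 2.5, with an estimated range from 2 to 3.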

Compound 3, distribution coefficient: 2.37
Compound 3: the middle estimate sits 0.13 log units above what was measured, within the range that was stated.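

Among these compounds, this is the first measured step, and it shows that the group on this oxygen strongly affects the reading in this assay. Hydrogen in place of ethyl, which turns ethoxy into hydroxy, gives a number 1.11 log units lower from compound 2 to compound 3 (beyond the scatter), and the step is large. Among the compounds shown here, nothing measured so far explains why the change has this size.

A single step cannot show whether the reading follows the size of the group on this oxygen, and compound 1, which carries a different group there, has no number to test that idea. As far as these compounds go, it also remains open whether a methyl group on this oxygen would fall in the gap between compound 2 and compound 3, and how an amine in this place would read.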